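Compound 2 and a pyrazole swap in A2780 cells

The compounds below may be only part of what the source reports. "The series", "measured", "known", "first", "only" and "open" are said of these compounds alone.

- compound 1 `CCCNCc1cc(-c2c(C(=O)NCC)noc2-c2cc(C(C)C)c(O)cc2O)on1`: "not determined" (no result reported)
- compound 2 `CCNC(=O)c1noc(-c2cc(C(C)C)c(O)cc2O)c1-c1cc(C(=O)NC)no1`: 100 nM

Going by the values given here, in a functional assay on A2780 cells (Homo sapiens) for inhibition (on this read-out lower numbers stand for stronger inhibition and higher numbers for weaker inhibition), compound 2 gives 100 nM, the only number available, since compound 1 has no reported result. Compound 2 therefore cannot yet be ranked against anything. Compound 3 `CCNC(=O)c1noc(-c2cc(C(C)C)c(O)cc2O)c1-c1ccn(CC)n1` keeps the shared core, with 1-ethyl-1H-pyrazol-3-yl in place of 3-(methylcarbamoyl)-1,2-oxazol-5-yl on an aromatic carbon. Among the compounds with values here, no measured step between related compounds is available as a guide, so the expectation is tentative. A modest gain in inhibition is expected, with an estimated step of a 1.7-fold lower number from compound 2 to compound 3 (0.22 log units; within the scatter). For compound 3, the expected value in this assay is 60 nM, with an estimated range of 15 nM to 250 nM.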

Compound 3, half-maximal inhibitory concentration: 13 nM
The estimate for compound 3 lay 4.6-fold (0.66 log units) above the measured number; the whole stated range lies above it.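

Placing 1-ethyl-1H-pyrazol-3-yl instead of 3-(methylcarbamoyl)-1,2-oxazol-5-yl on this aromatic carbon gives a 7.7-fold lower number from compound 2 to compound 3 (0.89 log units; beyond the scatter) in this assay. Going by these compounds alone, this is the first sign that inhibition responds to the group at this position, and it shows that the methylcarbamoyl group is not required for a low number here. No measured evidence bears on why the step has this size.

Going by these compounds, it remains open whether the step comes from the pyrazole ring itself or from the loss of the methylcarbamoyl group. On these data alone, it is also open whether a methyl group or a propyl chain in place of the ethyl on the pyrazole would keep this inhibition.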